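Swapping One Side Chain on a Shared Core

A few compounds are considered here, and "the series" means these few. Any claim that something is new, unique, unknown or untested is made for them only; others in the source may bear on it.

Of the compounds shown here, two with a shared core have been measured so far in a physicochemical assay for solubility, in phosphate buffer, with a stated time of 18 h, at pH 7.4; a lower number here means a less soluble compound, a higher number a more soluble compound. Compound 1 `COCCOc1cc2ncnc(-n3nc(-c4ccccn4)nc3N)c2cc1OCCOC` gives 30000 nM, and compound 2 `COc1cc2ncnc(-n3nc(-c4ccccn4)nc3N)c2cc1OCCCN(C)C` gives 53000 nM. These two numbers lie within the usual scatter of repeated measurements, so compound 2 stands level with compound 1 on the evidence so far.

Compound 3 `COCCOc1cc2c(-n3nc(-c4ccccn4)nc3N)ncnc2cc1OC` has not yet been measured. It differs from compound 2 in one place: methoxy in place of (dimethylamino)methyl on a saturated chain carbon, two bonds along the chain from an oxygen on an aromatic ring. Methoxy takes the place of (dimethylamino)methyl on a saturated chain carbon, two bonds along the chain from an oxygen on an aromatic ring, so 3-(dimethylamino)propoxy becomes 2-methoxyethoxy. Among the measured compounds shown here, no measured pair shows this change directly. The nearest guide is compound 1, which also carries 2-methoxyethoxy and gives 30000 nM in this assay. The expected result is a modest fall, estimated as a 2.1-fold lower number from compound 2 to compound 3 (0.33 log units; beyond the scatter), and it may barely clear the scatter. For compound 3 the estimated solubility is 25000 nM, with an expected range from 8000 nM to 60000 nM.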

Compound 3, solubility: 8000 nM
For compound 3 the middle estimate is 3.1-fold (0.49 log units) above the measured one, within the range that was stated.
By their numbers in this assay, from the lowest: compound 3; then compounds 1 and 2 (each within the scatter of the next).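

Compounds 1 and 2 stood level in this assay, so until now no change on the shared core had given a step beyond the scatter. Compound 3 provides the first such steps: putting methoxy in place of (dimethylamino)methyl, which turns 3-(dimethylamino)propoxy into 2-methoxyethoxy, gives a 6.6-fold lower number from compound 2 to compound 3 (0.82 log units; beyond the scatter), while hydrogen in place of methoxymethyl on a saturated chain carbon bound to an oxygen on an aromatic ring gives a 3.8-fold lower number from compound 1 to compound 3 (0.57 log units; beyond the scatter). Compound 3 therefore stands lowest of the three, yet 2-methoxyethoxy does not by itself go with a low number, as compound 1 also carries that group and gives 30000 nM.

Going by these compounds, the step from compound 2 changes the end of the chain and its length together, so these compounds cannot separate the two, and what a longer chain ending in methoxy or a chain ending in a carboxylic acid would give stays open. Nothing shown here offers a measured explanation for the size of either step.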